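A Second Chloro Group Added to Compound 2

The compounds below may be only part of what the source reports. "The series", "measured", "known", "first", "only" and "open" are said of these compounds alone.

Of the compounds shown here, two built on one shared core have been measured in an assay for inhibition of Intestinal-type alkaline phosphatase (Homo sapiens), read by spectrophotometry, with stated times of 10 min and 20 min; on this read-out lower numbers stand for stronger inhibition and higher numbers for weaker inhibition. Compound 1 `O=C1/C(=C/c2cccc(Br)c2)NS(=O)(=O)c2ccccc21` gives 2550 nM in this assay. Compound 2 `O=C1/C(=C/c2ccc(Cl)cc2)NS(=O)(=O)c2ccccc21` gives 4350 nM in this assay. Within the data shown here, the single step between them, a 1.7-fold higher number from compound 1 to compound 2 (0.23 log units; within the scatter), lies within the scatter. Compound 2 thus holds the higher of the two numbers shown, but the gap to compound 1 is within the scatter and so means no real difference.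

Compound 3 `O=C1/C(=C/c2ccc(Cl)cc2Cl)NS(=O)(=O)c2ccccc21` has not yet been measured in this assay. It differs from compound 2 by chloro in place of hydrogen on an aromatic carbon. Among the measured compounds shown here, the only measured step, an exchange of one substituent for another from compound 1 to compound 2, was within the scatter, and no measured step adds a second group to that ring, so nothing here points to a step beyond the scatter. The expected step is a 1.1-fold lower number from compound 2 to compound 3 (0.04 log units; within the scatter). For compound 3 the estimate in this assay is 4000 nM, with a range from 1500 nM to 11000 nM.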

Compound 3, half-maximal inhibitory concentration: 4960 nM
Compound 3: middle estimate off by 1.2-fold (0.09 log units), on the low side, and the stated range covers the measured number.
By their numbers in this assay, from the lowest: compounds 1, 2 and 3 (each within the scatter of the next).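

Chloro in place of hydrogen on an aromatic carbon, ortho to a large group and meta to a chloro group, gives a 1.1-fold higher number from compound 2 to compound 3 (0.06 log units; within the scatter) in this assay and so makes no real difference. Unlike the earlier step, which exchanged one substituent for another, this one adds a second group to the ring, and the added chlorine atom does not move the number beyond the scatter. Nothing available explains this result.

From the compounds shown here alone, whether an amine, a hydroxyl group or a carboxylic acid on this same aromatic carbon would give a number beyond the scatter remains open. Also open is whether any change to the shared core can produce a real difference, as every step shown so far lies within the scatter.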